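The compounds below may be only part of what the source reports. "The series", "measured", "known", "first", "only" and "open" are said of these compounds alone.

Measured compounds:
compound 1, `Cc1cc(C)c(CN2CCc3c(Cl)cc([C@H](CO)[C@H]4CCOC4)c(Cl)c3C2=O)c(=O)[nH]1` — 21.3 uL/min
compound 2, `Cc1cc(C)c(CN2CCc3c(Cl)cc([C@H](CO)[C@H]4CCCO4)c(Cl)c3C2=O)c(=O)[nH]1` — 51.6 uL/min
compound 3, `COC(c1cc(Cl)c2c(c1Cl)C(=O)N(Cc1c(C)cc(C)[nH]c1=O)CC2)C1CCS(=O)(=O)CC1` — 15 uL/min; 40 uL/min (2 entries)

Of the compounds shown here, three sharing one core have been tested in an ADME assay on microsomes from liver (Homo sapiens) for metabolic stability, read by LC-MS, using NADPH, with stated times of 10 min and 45 min, tested at 1 uM; on this read-out higher numbers stand for fast clearance and lower numbers for slow clearance. Compound 2 stands highest of the two single numbers; its nearest neighbour is compound 1, and the change between them is a 2.4-fold higher number from compound 1 to compound 2 (0.38 log units; beyond the scatter). Compound 3 has been run more than once, and the spread of its entries, (the several entries of compound 3 in this assay, 15 uL/min; 40 uL/min (2 entries)), shows how much repeated runs of this assay can differ.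

Compound 4, `Cc1cc(C)c(CN2CCc3c(Cl)cc(-c4c(C)noc4C)c(Cl)c3C2=O)c(=O)[nH]1`, differs from compound 2 in one place: a group of 7 heavy atoms (5 carbon, 1 nitrogen, 1 oxygen; one five-membered aromatic ring with 2 hetero atoms) in place of a group of 8 heavy atoms (6 carbon, 2 oxygen; one five-membered non-aromatic ring with 1 hetero atom), on an aromatic carbon.

Among the compounds with values here, none of the measured steps bears directly on this change. Within the data shown here, the only step available, from compound 1 to compound 2, concerns oxolan-2-yl in place of oxolan-3-yl on the saturated chain carbon, whereas compound 4 replaces that whole group, together with its hydroxymethyl-bearing carbon, by an aromatic ring bound directly to the core. Among the measured compounds shown here, the evidence therefore gives no direction for the step, and the repeat entries of compound 3 warn that a single run is uncertain.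

The step from compound 2 to compound 4 in this assay is expected to be a 1.7-fold lower number from compound 2 to compound 4 (0.24 log units; within the scatter), which is judged as no clear change beyond the scatter. Compound 4 is estimated to give 30 uL/min, within a range from 10 uL/min to 90 uL/min.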

Compound 4, intrinsic clearance in a liver preparation (reported as CLH), per the amount of preparation that the assay uses: 107 uL/min
For compound 4 the middle estimate is 3.6-fold (0.55 log units) below the measured one; the measured number lies above the stated range.
By their numbers in this assay, from the lowest: compound 1; then compound 2; then compound 4.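

Putting 3,5-dimethyl-1,2-oxazol-4-yl on this aromatic carbon, in place of the saturated side chain, gives a 2.1-fold higher number from compound 2 to compound 4 (0.32 log units; beyond the scatter) in this assay, and the same kind of replacement gives a 5.0-fold higher number from compound 1 to compound 4 (0.70 log units; beyond the scatter). The earlier step showed only that the read-out at this position responds to moving the attachment point on the oxolane ring, whereas these two steps show that replacing the whole group with an aromatic ring moves the number towards fast clearance from both oxolane compounds, and both steps lie beyond the usual scatter. Both steps rest on single numbers, so their size has to be weighed against how far repeated runs can differ: the several entries of compound 3 in this assay, 15 uL/min; 40 uL/min (2 entries)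

The change alters several things at once, including the ring type, the hydrogen-bond donor and the two defined stereocentres, and the compounds shown do not tell which of these goes with the higher number. On these data alone, it also remains open where a 1,2-oxazol-4-yl group without its two methyl groups, a phenyl ring or an oxolane ring bound directly to the aromatic carbon would fall in this assay.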